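Benzyl Esters of Two Related Cores in a Cell Assay

The source may report more compounds than this note shows. Statements on the series, on what has been measured and on what is new or still open speak of the compounds shown alone.

The series rests on two cores. Compound 1 `C=C1CC[C@H]2[C@@](C)(CC[C@@H](O)[C@@]2(C)C(=O)OC)[C@@H]1/C=C/C1=CCOC1=O` carries a methyl ester and a free hydroxyl; in a functional assay on NIH3T3 cells (Mus musculus) for inhibition, read by MTT assay, with a stated time of 72 h (a higher number here means a weaker inhibitor, a lower number a stronger inhibitor), compound 1 gives 111000 nM. Compound 2 `C=C1CC[C@H]2[C@@](C)(CC[C@@H](O)[C@@]2(C)C(=O)OCc2ccccc2)[C@@H]1/C=C/C1=CCOC1=O` differs from it by phenyl in place of hydrogen on a saturated chain carbon bound to an oxygen next to a carbonyl group, and in this assay compound 2 gives 13600 nM, which is an 8.2-fold lower number from compound 1 to compound 2 (0.91 log units; beyond the scatter). Compound 3 `C=C1CC[C@H]2[C@@](C)(CC[C@@H](OC(C)=O)[C@@]2(C)C(=O)OC)[C@@H]1C/C=C1\C=COC1=O` stands on a core whose difference from that of compound 1 is not broken down here; in this assay compound 3 gives 69700 nM. Compound 4 `C=C1CC[C@H]2[C@@](C)(CC[C@@H](OC(C)=O)[C@@]2(C)C(=O)OCc2ccccc2)[C@@H]1C/C=C1\C=COC1=O` has not yet been measured and differs from compound 3 by phenyl in place of hydrogen on a saturated chain carbon bound to an oxygen next to a carbonyl group, the same change seen once already. Because the earlier step was an 8.2-fold lower number from compound 1 to compound 2 (0.91 log units; beyond the scatter), a step of similar size is expected, estimated at a 7.0-fold lower number from compound 3 to compound 4 (0.84 log units; beyond the scatter). For compound 4 the expected value in this assay is 10000 nM, within 3000 nM to 35000 nM.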

Compound 4, half-maximal inhibitory concentration: 78000 nM
Beside the measured number, compound 4's estimate is 7.8-fold (0.89 log units) below it, and the stated range ends below it.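

On the second core, the change from methyl to benzyl at the ester gave a 1.1-fold higher number from compound 3 to compound 4 (0.05 log units; within the scatter) in this assay, so no shift beyond the scatter appears there. The gain seen on the core of compound 1 therefore does not carry over to the core of compound 3: the same change on two cores in this assay, an 8.2-fold lower number (0.91 log units; beyond the scatter) from compound 1 to compound 2 and a 1.1-fold higher number (0.05 log units; within the scatter) from compound 3 to compound 4, 9.1-fold (0.96 log units) apart, beyond the scatter of two such steps This rests on a single pair for each core, and it does not show which difference between the two cores decides the outcome.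

The compounds shown leave open whether the benzyl ester's effect follows the free hydroxyl of compound 1 or some other feature of that core. They also leave open how an ethyl ester, a longer chain or an amide at the same place would behave on either core.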